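Removing one chloro from compound 2

A few compounds are considered here, and "the series" means these few. Any claim that something is new, unique, unknown or untested is made for them only; others in the source may bear on it.

Compound 1 `Cn1cncc1C(OCc1ccc(C#N)nc1-c1ccc2ccccc2c1)c1ccc(C#N)cc1`: 7.4 nM
Compound 2 `Cn1cncc1C(OCc1ccc(C#N)nc1-c1cc(Cl)cc(Cl)c1)c1ccc(C#N)cc1`: 6 nM
Compound 3 `Cn1cncc1C(OCc1ccc(C#N)nc1-c1cccc(Cl)c1)c1ccc(C#N)cc1`: not yet measured

Going by the values given here, in a functional assay on NIH3T3 cells (Mus musculus) (a lower number here means that less compound is needed, a higher number that more compound is needed for the effect), compound 2 gives 6 nM, and the only other measured compound lies within the scatter of it. Compound 3 keeps the same core but goes from 3,5-dichlorophenyl to 3-chlorophenyl, with hydrogen in place of chloro on an aromatic carbon. Among the compounds with values here, no measured pair shows this exact change. The nearest evidence is a 1.2-fold lower number from compound 1 to compound 2 (0.09 log units; within the scatter), a swap of the whole group from naphthalen-2-yl to 3,5-dichlorophenyl. That single small step is only indirect guidance, so a small change is expected here too, with a slight rise in the number and nothing clearly beyond the scatter. The expected step is a 1.5-fold higher number from compound 2 to compound 3 (0.18 log units; within the scatter). For compound 3 the estimated value is 9 nM, with an expected range from 3.5 nM to 22 nM.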

Compound 3, half-maximal effective concentration: 1.8 nM
The estimate for compound 3 lay 5.0-fold (0.70 log units) above the measured number, and the stated range ends above it.
By their numbers in this assay, from the lowest: compound 3; then compounds 2 and 1 (each within the scatter of the next).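

In this assay, going by these compounds alone, removing one chloro from the 3,5-dichlorophenyl group gives a 3.3-fold lower number from compound 2 to compound 3 (0.52 log units; beyond the scatter) and is the first single change here that lies beyond the scatter, so this ring responds to the loss of one heavy atom. The 3-chlorophenyl group also separates from naphthalen-2-yl, with a 4.1-fold lower number from compound 1 to compound 3 (0.61 log units; beyond the scatter), even though the 3,5-dichlorophenyl and naphthalen-2-yl groups lie within the scatter of each other, so a larger change of group at this position did less than removing one chloro. No independent measurement here explains why the compound with one chloro needs a lower concentration.

Open, from the compounds shown here alone, is whether the remaining chloro contributes at all, which a plain phenyl group would show. Also open, going by these compounds, is whether a fluoro, a methoxy or an amine in its place would give a similar number.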